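Working notes: from compound 2 to compound 4

The compounds below may be only part of what the source reports. "The series", "measured", "known", "first", "only" and "open" are said of these compounds alone.

Measured in a functional assay on UACC-62 cells (Homo sapiens) for cytotoxicity, read by sulforhodamine B assay; on this read-out lower numbers stand for higher toxicity in this test and higher numbers for lower toxicity in this test:
- compound 1 `COc1ccc(/C=N\NC(=S)NC(C)(C)CCC[C@](C)(O)[C@@H]2CC=C(C)CC2)cc1` gives 48500 nM
- compound 2 `CC1=CC[C@@H]([C@@](C)(O)CCCC(C)(C)NC(=S)N/N=C\c2ccc(O)cc2)CC1` gives 55600 nM
- compound 3 `CC1=CC[C@@H]([C@@](C)(O)CCCC(C)(C)NC(=S)N/N=C\c2ccc(N(C)C)cc2)CC1` gives > 100000 nM, which is a limit of the assay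

Compound 2 sits within the scatter of compound 1, and compound 3 offers only a limit for comparison. Compound 4 `CC1=CC[C@@H]([C@@](C)(O)CCCC(C)(C)NC(=S)N/N=C\c2ccccc2Cl)CC1` has 2-chlorophenyl in place of 4-hydroxyphenyl on a carbon with a double bond to nitrogen. The nearest measured changes are a 1.1-fold higher number from compound 1 to compound 2 (0.06 log units; within the scatter), an at least 1.7-fold higher number from compound 2 to compound 3 (0.25 log units; that floor lies within the scatter) and an at least 2.0-fold higher number from compound 1 to compound 3 (0.31 log units; beyond the scatter). None of these introduces chlorine, so the basis is thin. No step beyond the scatter is therefore expected in this assay, in either direction. For compound 4 the estimate is 50000 nM, with an expected range of 20000 nM to 100000 nM. The expected step is a 1.1-fold lower number from compound 2 to compound 4 (0.05 log units; within the scatter).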

Compound 4, concentration lethal to 50% of the cells: > 100000 nM
Compound 4 was reported as a limit; the forecaster's own chance of this, stated with the estimate: 20%; at least 2.0-fold (0.30 log units) between middle value and limit.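

In this assay, within the data shown here, compound 4 gives > 100000 nM, a limit of the assay, and it is the first compound here with chlorine on the ring at this place. The change to 2-chlorophenyl gives an at least 1.7-fold higher number from compound 2 to compound 4 (0.25 log units; that floor lies within the scatter), and the change from 4-methoxyphenyl gives an at least 2.0-fold higher number from compound 1 to compound 4 (0.31 log units; beyond the scatter); only this second floor clears the scatter. The step between the two compounds at the limit cannot be read, and the ceiling now constrains the comparison: the limit of > 100000 nM in this assay, at which 2 of the 4 values shown sit.

Going by these compounds, the true size of the steps to compound 4 stays open. So does what a carboxylic acid or an amine on this ring would give.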